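The source may report more compounds than this note shows. Statements on the series, on what has been measured and on what is new or still open speak of the compounds shown alone.

Measured so far in an ADME assay on S9 fraction (Rattus norvegicus) for metabolic stability, with a stated time of 60 min; on this read-out higher numbers stand for a more stable compound and lower numbers for a less stable compound:

Compound 1 `CC(C)(O)c1ccc(-c2cnc3c(n2)N(CC2CCOCC2)C(=O)CN3)cn1` — 83%
Compound 2 `CO[C@H]1CC[C@H](CN2CC(=O)Nc3ncc(-c4ccc(C(C)(C)O)nc4)nc32)CC1` — 77%

Among the measured compounds shown here, compound 1 and compound 2 are the only two measured compounds; in this assay compound 1 gives 83% and compound 2 gives 77%, and the two numbers lie within the scatter of each other. Compound 3 `COCCN1C(=O)CNc2ncc(-c3ccc(C(C)(C)O)nc3)nc21` is not yet measured. It differs from compound 1 in one place: methoxymethyl in place of oxan-4-yl on a saturated chain carbon bound to an amide-type nitrogen in a ring. For the measured compounds named here, no step between measured compounds is known, so the step is expected to stay within the scatter, with no clear direction, at a number 5 percentage points lower from compound 1 to compound 3 (within the scatter). Compound 3 is therefore estimated at 78%, within a range from 60% to 92%.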

Compound 3, percent of the compound remaining: 89%
Compound 3: the middle estimate sits 11 percentage points below what was measured; low and high end bracket the measured number.
By their numbers in this assay, from the lowest: compounds 2, 1 and 3 (each within the scatter of the next, the first and the last beyond it).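

In this assay, putting methoxymethyl in place of oxan-4-yl on a saturated chain carbon bound to an amide-type nitrogen in a ring gives a number 6 percentage points higher from compound 1 to compound 3 (within the scatter). This first step read at this position shows that the ring can give way to an open chain, with 3 heavy atoms in place of 6, without a change beyond the scatter. Nothing available explains this result. From the compounds shown here alone, whether an amine, a carboxylic acid or a longer chain in place of methoxymethyl would also stay within the scatter remains open.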